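Carbonyl Substituent Swap at the Shared Core

The source may report more compounds than this note shows. Statements on the series, on what has been measured and on what is new or still open speak of the compounds shown alone.

Measured so far:
compound 1, `Cc1cn2cccc(OCc3ccccc3)c2n1`, gives 70% in a functional assay on the whole organism (stomach) for inhibition, with Canis familiaris (Canis lupus familiaris) as the target, at a dose of 5 mg/kg by the intravenous route; on this read-out lower numbers stand for a weaker effect and higher numbers for a stronger effect at the one dose given
compound 2, `Cc1nc2c(OCc3ccccc3)cccn2c1C(N)=O`, gives 2% in this assay

Compound 2 stands lowest of the two numbers; its nearest neighbour is compound 1, and the step of a number 68 percentage points lower from compound 1 to compound 2 (beyond the scatter) is beyond the scatter. It came with carbamoyl in place of hydrogen on an aromatic carbon.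

Compound 3, `CC(=O)c1c(C)nc2c(OCc3ccccc3)cccn12`, has not been measured yet. It differs from compound 2 as follows: methyl in place of amino on a carbonyl carbon.

No measured step bears directly on a change at the carbonyl carbon; the only step shown, a number 68 percentage points lower from compound 1 to compound 2 (beyond the scatter), tells that placing a carbamoyl on the aromatic carbon removed almost all of the inhibition seen for compound 1. Compound 3 keeps a carbonyl on that carbon, so the expectation for compound 3 is a number near that of compound 2, with an expected step of a number 18 percentage points higher from compound 2 to compound 3 (beyond the scatter) that may or may not exceed the scatter. Compound 3 is therefore estimated at 20%, with a range from 0% to 60%.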

Compound 3, a percentage reported as inhibition, in the whole organism at one dose (the size of the read-out at that dose, not a potency): 9%
The estimate for compound 3 lay 11 percentage points above the measured number; measured number inside the range.
By their numbers in this assay, from the lowest: compounds 2 and 3 (each within the scatter of the next); then compound 1.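

Exchanging the amino of the carbamoyl for methyl on the carbonyl carbon, which turns carbamoyl into acetyl, gives a step in this assay of a number 7 percentage points higher from compound 2 to compound 3 (within the scatter). Among these compounds, the hydrogen-bond donor that leaves with the amino group therefore makes no difference that this read-out can separate from scatter, a point the single earlier step could not settle. The acetyl group on the aromatic carbon also brings a large loss, a number 61 percentage points lower from compound 1 to compound 3 (beyond the scatter), so among these compounds the loss is not tied to carbamoyl alone but appears with both carbonyl-bearing groups; nothing available explains why the inhibition falls with either group.

The two substituted compounds both carry a carbonyl on that carbon, so they cannot show whether the carbonyl matters or whether any group there would bring the same loss; a plain methyl, a nitrile or a hydroxymethyl group would separate these readings. From the compounds shown here alone, a carboxylic acid or a longer ketone chain on the carbonyl carbon also remains open, as does whether the low numbers at this one dose would hold at other doses.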